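Shortening a Butoxy Chain on a Dihydrofolate Reductase Inhibitor

A few compounds are considered here, and "the series" means these few. Any claim that something is new, unique, unknown or untested is made for them only; others in the source may bear on it.

Measured compounds:
compound 1 `CCCCOc1ccccc1Cc1cnc(N)nc1N` gives 8710 nM
compound 2 `Cc1ccccc1Cc1cnc(N)nc1N` gives 29500 nM
compound 3 `COCc1ccccc1Cc1cnc(N)nc1N` gives 39800 nM

These three compounds share one core and differ only in the group carried on the aromatic ring. In an assay for inhibition of Dihydrofolate reductase (Gallus gallus) (a higher number here means a weaker inhibitor, a lower number a stronger inhibitor), compound 1 holds the lowest number of the three, which here means the strongest inhibition. Its nearest neighbour is compound 2, reached by a 3.4-fold higher number from compound 1 to compound 2 (0.53 log units; beyond the scatter); the furthest is compound 3, reached by a 4.6-fold higher number from compound 1 to compound 3 (0.66 log units; beyond the scatter). Between compound 2 and compound 3 the step is a 1.3-fold higher number from compound 2 to compound 3 (0.13 log units; within the scatter), so those two cannot be ordered.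

The unmeasured compound 4 `COc1ccccc1Cc1cnc(N)nc1N` is made from compound 1 by the change (hydrogen in place of propyl on a saturated chain carbon bound to an oxygen on an aromatic ring).

Two of the measured steps bear on this: in both, the butoxy of compound 1 gave way to a smaller group, and in both the number rose by a modest but real amount. A methoxy is also a smaller group than butoxy, so a rise of similar size is expected here, in the direction of weaker inhibition.

Compound 4 is therefore expected to give 25000 nM in this assay, within a range of 9000 nM to 60000 nM. This estimate corresponds to an expected step of a 2.9-fold higher number from compound 1 to compound 4 (0.46 log units; beyond the scatter).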

Compound 4, inhibition constant: 28800 nM
Compound 4: the middle estimate sits 1.2-fold (0.06 log units) below what was measured; the measured number falls inside the stated range.
By their numbers in this assay, from the lowest: compound 1; then compounds 4, 2 and 3 (each within the scatter of the next).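

In this assay, cutting the butoxy of compound 1 back to methoxy leaves an oxygen on the aromatic ring, yet the number still rises, with a 3.3-fold higher number from compound 1 to compound 4 (0.52 log units; beyond the scatter). The oxygen on the ring is therefore not enough to keep the low number of compound 1, and among these four compounds only compound 1, the one with the butoxy chain, stands apart from the rest. The three smaller groups cannot be ordered at this position: the change from methoxymethyl to methoxy gives a 1.4-fold lower number from compound 3 to compound 4 (0.14 log units; within the scatter), and the change from methyl to methoxy gives a 1.0-fold lower number from compound 2 to compound 4 (0.01 log units; within the scatter), so both steps stay within the scatter.

Nothing in the data available here explains why the butoxy compound holds the lowest number. Still open, from the compounds shown here alone, is how the number moves along the series of chains between methoxy and butoxy, such as ethoxy and propoxy, whether a longer chain such as pentyloxy would lower it further, and whether a butyl chain without the oxygen, or one ending in an amine or a carboxylic acid, would behave like butoxy.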